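Swapping bromo for pyridin-2-yl at a cytotoxicity limit

A few compounds are considered here, and "the series" means these few. Any claim that something is new, unique, unknown or untested is made for them only; others in the source may bear on it.

Compound 1 `CNC(=O)[C@@H](NC(=O)[C@@](O)(CCCN(Cc1ccc(Br)cc1)NC(=O)[C@@H](NC(=O)OC)C(C)(C)C)Cc1ccccc1)C(C)(C)C`: > 10000 nM
Compound 2 `CNC(=O)[C@H](C)NC(=O)[C@@](O)(CCCN(Cc1ccc(Br)cc1)NC(=O)[C@@H](NC(=O)OC)C(C)(C)C)Cc1ccccc1`: > 10000 nM
Compound 3 `CNC(=O)[C@@H](NC(=O)[C@@](O)(CCCN(Cc1ccc(-c2cccnc2)cc1)NC(=O)[C@@H](NC(=O)OC)C(C)(C)C)Cc1ccccc1)C(C)(C)C`: > 50000 nM

In an ADME assay on MT4 cells (Homo sapiens) for cytotoxicity, read by XTT assay, with a stated time of 5 days (a higher number here means that more compound is tolerated, a lower number that less compound is tolerated), compound 1 gives > 10000 nM, which is a limit and not a number. Compound 2 gives > 10000 nM, also a limit. Compound 3 gives > 50000 nM, again a limit. Compound 1 therefore stands at the limit of > 10000 nM in this assay, at which 2 of the 3 values shown sit, while the remaining value is the limit of > 50000 nM in this assay, at which 1 of the 3 values shown sits.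

The step followed here leads to compound 4 `CNC(=O)[C@@H](NC(=O)[C@@](O)(CCCN(Cc1ccc(-c2ccccn2)cc1)NC(=O)[C@@H](NC(=O)OC)C(C)(C)C)Cc1ccccc1)C(C)(C)C`, which carries pyridin-2-yl in place of bromo on an aromatic carbon, para to a large group: pyridin-2-yl in place of bromo on an aromatic carbon.

The closest measured change is a step that the two limits leave unreadable from compound 1 to compound 3, where pyridin-3-yl replaces bromo. The other, a step that the two limits leave unreadable from compound 1 to compound 2, concerns tert-butyl and methyl elsewhere in the molecule and bears on this change less directly. Neither has a readable size, so none can be carried over. Resting on compound 3 and its step that the two limits leave unreadable from compound 1 to compound 3, the expectation in this assay is of no clear loss in tolerated compound, and most likely another limit.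

For compound 4 the estimated value is 40000 nM, with an expected range from 10000 nM to 100000 nM. The expected step, a step that the limit leaves unreadable from compound 1 to compound 4, is only nominal, as it starts from a limit.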

Compound 4, half-maximal cytotoxic concentration: > 50000 nM
Compound 4 ended at the assay's limit (the forecaster's own chance of this, stated with the estimate: 85%); at least 1.2-fold (0.09 log units) between middle value and limit.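

In this assay compound 4 gives > 50000 nM, which is a limit. With limits on both sides, neither the change from compound 1 to compound 4 nor the change from compound 3 to compound 4 can be read as a step. The compounds shown leave open where cytotoxicity would begin for any of them, and whether pyridin-2-yl and pyridin-3-yl differ at all.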